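This account rests on a few compounds, and the source may have more. Where it says the series, first, only, none or still open, it means among the compounds named here.

Measured so far in a functional assay on CHO cells for antagonist activity at adenosine receptor A2b (Homo sapiens), read by 33P incorporation, with a stated time of 20 min; on this read-out lower numbers stand for stronger inhibition and higher numbers for weaker inhibition:
compound 1, `Cn1c(-c2cccc(Cl)c2)nc2c(NC3CCCC3)ncnc21`: 2530 nM
compound 2, `Cn1c(-c2ccc(O)cc2)nc2c(NC3CCCC3)ncnc21`: 17800 nM
compound 3, `Cn1c(-c2ccc(Cl)cc2)nc2c(NC3CCCC3)ncnc21`: > 30000 nM, a limit of the assay rather than a number

For the measured compounds named here, compound 3 therefore stands at the weak end of this small set: its result is only a limit, the one value of the three that sits at the limit of > 30000 nM in this assay, at which 1 of the 3 values shown sits, so its true number is not known. Compound 4, `Cc1cccc(-c2nc3c(NC4CCCC4)ncnc3n2C)c1`, differs from compound 3 in one place: 3-methylphenyl in place of 4-chlorophenyl on an aromatic carbon.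

Going by the values given here, two measured steps bear on this change. The first is an at least 11-fold higher number from compound 1 to compound 3 (1.07 log units; beyond the scatter), which shows the 3-chlorophenyl compound far stronger than the 4-chlorophenyl one. The second is an at least 1.6-fold higher number from compound 2 to compound 3 (0.22 log units; that floor lies within the scatter), a floor that lies within the scatter and adds little. Compound 4 carries a 3-methylphenyl, so the move from compound 3 reverses the substitution pattern that cost so much in the first step; a return toward the level of compound 1 is expected, with some uncertainty since methyl is not chloro. The step is expected as an at least 7.5-fold lower number from compound 3 to compound 4 (0.87 log units; beyond the scatter). Compound 4 is thus estimated at 4000 nM, within a range from 1500 nM to 15000 nM.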

Compound 4, inhibition constant: 6030 nM
Beside the measured number, compound 4's estimate is 1.5-fold (0.18 log units) below it; measured number inside the range.
By their numbers in this assay, from the lowest: compound 1; then compound 4; then compound 2. At a limit, above all of these: compound 3.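

In this assay, 3-methylphenyl on the aromatic carbon between two ring nitrogen atoms gives a measurable number where 4-chlorophenyl did not, with an at least 4.9-fold lower number from compound 3 to compound 4 (0.69 log units; beyond the scatter). The advantage over a group named with 4 is therefore not confined to chlorine: 3-methylphenyl also improves on 4-hydroxyphenyl, with a 3.0-fold lower number from compound 2 to compound 4 (0.47 log units; beyond the scatter). Yet methyl does not fully match chloro at this position, as a 2.4-fold higher number from compound 1 to compound 4 (0.38 log units; beyond the scatter) shows.

Going by these compounds, compound 3 remains a limit of the assay and not a number, so the true size of its steps stays open: the limit of > 30000 nM in this assay, at which 1 of the 4 values shown sits. Also open, on these data alone, is how 4-methylphenyl would compare with 3-methylphenyl, and whether an amine or a carboxylic acid on the phenyl ring would be tolerated.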